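Replacing 2-methylphenyl with hydrogen in compound 3

The source may report more compounds than this note shows. Statements on the series, on what has been measured and on what is new or still open speak of the compounds shown alone.

In a functional assay on KB cells (Homo sapiens) for cytotoxicity (on this read-out lower numbers stand for stronger inhibition and higher numbers for weaker inhibition), compound 3 `Cc1ccccc1Cn1cc(C(=N)S)c2c(N)ncnc21` gives > 17000 nM, which is a limit and not a number. Two close relatives do give numbers: compound 1 `CCOCn1cc(C(=N)S)c2c(N)ncnc21` gives 68000 nM, and compound 2 `Cc1ccc(Cn2cc(C(=N)S)c3c(N)ncnc32)cc1` gives 65000 nM. All three share a core and differ only in the group on a saturated chain carbon bound to an aromatic nitrogen.

Compound 4 `Cn1cc(C(=N)S)c2c(N)ncnc21` changes that same place, with hydrogen in place of 2-methylphenyl on a saturated chain carbon bound to an aromatic nitrogen. Here, hydrogen stands in place of 2-methylphenyl. For the measured compounds named here, the steps a step that the limit leaves unreadable from compound 1 to compound 3 and a step that the limit leaves unreadable from compound 2 to compound 3 cannot guide a prediction, so the only readable evidence is a 1.0-fold lower number from compound 1 to compound 2 (0.02 log units; within the scatter). Swapping ethoxy for 4-methylphenyl there left the two values within the scatter, so no large change is expected from this new swap, and a number close to those of compound 1 and compound 2 seems likely.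

Measured against a limit, the expected step is a step that the limit leaves unreadable from compound 3 to compound 4. For compound 4, the estimated value is 60000 nM, with an expected range of 20000 nM to 150000 nM.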

Compound 4, half-maximal inhibitory concentration: 15000 nM
Compound 4: middle estimate off by 4.0-fold (0.60 log units), on the high side; the whole stated range lies above it.
By their numbers in this assay, from the lowest: compound 4; then compounds 2 and 1 (each within the scatter of the next).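

In this assay, hydrogen on the saturated chain carbon bound to an aromatic nitrogen gives a 4.3-fold lower number from compound 2 to compound 4 (0.64 log units; beyond the scatter) and a 4.5-fold lower number from compound 1 to compound 4 (0.66 log units; beyond the scatter). So this place does respond to change, even though ethoxy and 4-methylphenyl left the number within the scatter of each other. The remaining step, an at least 1.1-fold lower number from compound 3 to compound 4 (0.05 log units; that floor lies within the scatter), gives only a floor, because one end of it is a limit and not a number: the limit of > 17000 nM in this assay, at which 1 of the 4 values shown sits.

The compounds shown leave open where 2-methylphenyl truly stands, and so whether moving the methyl on the phenyl ring matters at all. They also leave open whether hydrogen alone stands apart, or whether a short ethyl chain, an amine or a carboxylic acid on this carbon would give a number like that of compound 4.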